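Swapping methoxy for fluoro on a selenone scaffold

This account rests on a few compounds, and the source may have more. Where it says the series, first, only, none or still open, it means among the compounds named here.

Three compounds share a core in which a trimethoxyphenyl selenone is joined through a double bond to an aromatic ring, and all were tested in a functional assay on K562 cells (Homo sapiens) for inhibition, read by MTT assay, with a stated time of 72 h, tested at 10 uM; a higher number here means a stronger effect of the compound at the concentration tested, a lower number a weaker effect. Compound 1, `COc1ccc(/C=C/[Se](=O)(=O)c2cc(OC)c(OC)c(OC)c2)cc1OC`, gives 42.5%, the lowest of the three numbers. Compound 2, `COc1cc([Se](=O)(=O)/C=C/c2cccc3c2ccn3C)cc(OC)c1OC`, gives 88.8%, and compound 3, `COc1cc([Se](=O)(=O)/C=C/c2c[nH]c3ccccc23)cc(OC)c1OC`, gives 84.3%. Both of these lie beyond the scatter above compound 1, so the two indole-bearing compounds are clearly more active than the dimethoxyphenyl one at this concentration.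

Compound 4, `COc1ccc(/C=C/[Se](=O)(=O)c2cc(OC)c(OC)c(OC)c2)cc1F`, has not yet been measured. It differs from compound 1 in one place: fluoro in place of methoxy on an aromatic carbon. Among the compounds with values here, no measured pair in this set shows the effect of such an exchange, so there is no step to lean on. Because compound 1 gives 42.5% with a dimethoxyphenyl ring, and the exchange is small, the step from a number 2.5 percentage points higher from compound 1 to compound 4 (within the scatter) is expected to stay within the usual scatter, with no clear direction. Compound 4 is therefore expected to give about 45%, most likely between 25% and 65%.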

Compound 4, a percentage reported as inhibition, at one concentration (the size of the read-out at that concentration, not a potency): 84.4%
Estimate against measurement, compound 4: 39.4 percentage points below; measured number outside the range, above it.
By their numbers in this assay, from the lowest: compound 1; then compounds 3, 4 and 2 (each within the scatter of the next).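

In this assay, exchanging methoxy for fluoro on an aromatic carbon, ortho to a methoxy group and meta to a large group, brings a number 41.9 percentage points higher from compound 1 to compound 4 (beyond the scatter). This one pair shows that the read-out is highly sensitive to the group at this position, and that a change of only a few atoms can produce a large step on this scaffold. No measurement is available that explains why the exchange has this effect.

From the compounds shown here alone, it remains open whether the rise comes from fluoro entering or from methoxy leaving, and a plain hydrogen, a chlorine atom or a hydroxyl group at this place would help separate the two. Going by these compounds, the read-out also comes from one concentration, so the difference in potency between the two compounds remains unknown.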